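The source may hold more compounds than are shown below. What is called first, only, known or untested is meant among the compounds shown, and "the series" means these compounds.

Compound 3 `CNC(=O)c1cccc(S(=O)(=O)Oc2ccc(-c3cncn3C3CCN(C(=O)c4ccc([N+](=O)[O-])cc4)CC3)cc2)c1` gives 62 nM in an assay on HEK293 cells for antagonist activity at P2X purinoceptor 7 (Homo sapiens), read by fluorescence, with a stated time of 2 h (on this read-out higher numbers stand for weaker inhibition and lower numbers for stronger inhibition), the second highest of the three numbers at hand. Compound 1 `O=C(NC1CC1)c1cccc(S(=O)(=O)Oc2ccc(-c3cncn3C3CCN(C(=O)c4ccc(Cl)c(C(F)(F)F)c4)CC3)cc2)c1` gives 88 nM, within the scatter of compound 3; compound 2 `O=C(c1ccc([N+](=O)[O-])cc1)N1CCC(n2cncc2-c2ccc(OS(=O)(=O)c3cccc4cnccc34)cc2)CC1` gives 1.49 nM. The only single step among these, a 42-fold higher number from compound 2 to compound 3 (1.62 log units; beyond the scatter), concerns the aryl on the sulfonyl sulfur and not the change at issue. Compound 4 `O=C(NC1CC1)c1cccc(S(=O)(=O)Oc2ccc(-c3cncn3C3CCN(C(=O)c4ccc([N+](=O)[O-])cc4)CC3)cc2)c1` differs from compound 3 by cyclopropyl in place of methyl on an amide-type nitrogen. Within the data shown here, compound 1 already carries cyclopropylcarbamoyl and its number sits within the scatter of compound 3, though its benzoyl also differs, so no step bears directly on this change. The expected step of a 1.0-fold lower number from compound 3 to compound 4 (0.01 log units; within the scatter) is none beyond the scatter. For compound 4 an estimate of 60 nM is made, with a range of 25 nM to 150 nM.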

Compound 4, half-maximal inhibitory concentration: 152 nM
Estimate against measurement, compound 4: 2.5-fold (0.40 log units) below; measured number above the stated range.
By their numbers in this assay, from the lowest: compound 2; then compounds 3, 1 and 4 (each within the scatter of the next, the first and the last beyond it).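

In this assay, among these compounds, the substituent on this amide-type nitrogen proves able to move the number: cyclopropyl in place of methyl gives a 2.5-fold higher number from compound 3 to compound 4 (0.39 log units; beyond the scatter) as the first direct reading at this position. With cyclopropylcarbamoyl fixed, isoquinolin-5-yl on the sulfonyl sulfur remains far ahead, with a 100-fold higher number from compound 2 to compound 4 (2.01 log units; beyond the scatter) on replacing it, whereas the change on the carbonyl carbon gives only a 1.7-fold higher number from compound 1 to compound 4 (0.24 log units; within the scatter) and stays unresolved. Nothing at hand explains the step at this nitrogen.

On these data alone, whether ethyl, tert-butyl or a longer chain ending in an amine would extend this step on the nitrogen remains open. Also open, as far as these compounds go, is whether the step holds with 4-chloro-3-(trifluoromethyl)phenyl on the carbonyl carbon.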